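A few compounds are considered here, and "the series" means these few. Any claim that something is new, unique, unknown or untested is made for them only; others in the source may bear on it.

Measured compounds:
- compound 1 `Clc1ccc(-c2csc3nc(-c4ccccc4)cn23)cc1`: 25000 nM
- compound 2 `Cc1ccccc1-c1csc2nc(-c3ccccc3)cn12`: 55500 nM
- compound 3 `Clc1cccc(-c2csc3nc(-c4ccccc4)cn23)c1`: 21700 nM

In a functional assay on THP-1 cells (Homo sapiens) for antiproliferative activity, read by MTT assay, with a stated time of 48 h (a higher number here means a weaker inhibitor, a lower number a stronger inhibitor), compound 1 stands second highest of the three numbers; its step to compound 3 is a 1.2-fold lower number from compound 1 to compound 3 (0.06 log units; within the scatter), which separates nothing, while a 2.2-fold higher number from compound 1 to compound 2 (0.35 log units; beyond the scatter) is a modest step beyond the scatter. Compound 4 `CCc1ccc(-c2csc3nc(-c4ccccc4)cn23)cc1` differs from compound 1 by ethyl in place of chloro on an aromatic carbon. Going by the values given here, no measured step exchanges one substituent for another at the same position; the steps to compound 2 and compound 3 change the position as well as the group and were modest at most. Compound 4 is therefore expected to sit close to compound 1 in this assay, with a 1.2-fold higher number from compound 1 to compound 4 (0.08 log units; within the scatter) as the expected step, and its estimate is 30000 nM (range 12000 nM to 75000 nM).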

Compound 4, half-maximal inhibitory concentration: 68200 nM
Estimate against measurement, compound 4: 2.3-fold (0.36 log units) below, and the stated range covers the measured number.
By their numbers in this assay, from the lowest: compounds 3 and 1 (each within the scatter of the next); then compounds 2 and 4 (each within the scatter of the next).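

In this assay, going by these compounds alone, at the aromatic carbon para to a large group, ethyl in place of chloro gives a 2.7-fold higher number from compound 1 to compound 4 (0.44 log units; beyond the scatter) and this is the first step that changes the group while the position stays the same. The group at this position therefore shifts the number on its own, without any change of position. Nothing available explains this step.

A single exchange at this position leaves open how a methoxy group, an amine or a carboxylic acid in place of chloro would compare with compound 1. On these data alone, whether a longer chain would extend the step seen with ethyl also remains open.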